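This account rests on a few compounds, and the source may have more. Where it says the series, first, only, none or still open, it means among the compounds named here.

Measured compounds:
compound 1 `COc1cc(-n2cnc3ccc(-c4ccc([N+](=O)[O-])cc4)cc32)cc(OC)c1OC`: 79 nM
compound 2 `COc1ccc(-c2ccc3ncn(-c4cc(OC)c(OC)c(OC)c4)c3c2)cc1`: 82 nM
compound 3 `COc1cc(-n2cnc3ccc(-c4cccc([N+](=O)[O-])c4)cc32)cc(OC)c1OC`: 380 nM

The three measured compounds share one core and differ only in the group carried on the pendant phenyl ring. In a functional assay on SGC-7901 cells (Homo sapiens) for antiproliferative activity, read by MTT assay, with a stated time of 72 h (on this read-out higher numbers stand for weaker inhibition and lower numbers for stronger inhibition), compound 1 gives 79 nM and compound 2 gives 82 nM; the step of a 1.0-fold higher number from compound 1 to compound 2 (0.02 log units; within the scatter) stays within the scatter. In this assay compound 3 gives 380 nM, the highest of the three numbers: the steps of a 4.8-fold higher number from compound 1 to compound 3 (0.68 log units; beyond the scatter) and a 4.6-fold higher number from compound 2 to compound 3 (0.67 log units; beyond the scatter) both lie beyond the scatter, though each is modest.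

Compound 4 `COc1cc(-n2cnc3ccc(-c4cccc(C)c4)cc32)cc(OC)c1OC` is reached from compound 3 by methyl in place of nitro on an aromatic carbon. For the measured compounds named here, no measured step exchanges nitro for methyl. Going by the values given here, the one step that swaps the nitro group for a different group, a 1.0-fold higher number from compound 1 to compound 2 (0.02 log units; within the scatter), is within the scatter, whereas the two steps that shift the group to another position, a 4.8-fold higher number from compound 1 to compound 3 (0.68 log units; beyond the scatter) and a 4.6-fold higher number from compound 2 to compound 3 (0.67 log units; beyond the scatter), are modest and upward. The change from compound 3 to compound 4 leaves the group where it is and only exchanges it, so a step no larger than the scatter is expected in this assay, without a firm direction. Compound 4 is therefore estimated at 320 nM in this assay, within 120 nM to 850 nM. This corresponds to an expected step of a 1.2-fold lower number from compound 3 to compound 4 (0.07 log units; within the scatter).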

Compound 4, half-maximal inhibitory concentration: 1240 nM
For compound 4 the middle estimate is 3.9-fold (0.59 log units) below the measured one; the whole stated range lies below it.
By their numbers in this assay, from the lowest: compounds 1 and 2 (each within the scatter of the next); then compound 3; then compound 4.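

In this assay, keeping the group in the same place on the pendant ring no longer guarantees a similar number: the exchange of nitro for methyl gives a modest step beyond the scatter (a 3.3-fold higher number from compound 3 to compound 4 (0.51 log units; beyond the scatter)), whereas the earlier exchange of nitro for methoxy stayed within it (a 1.0-fold higher number from compound 1 to compound 2 (0.02 log units; within the scatter)). The identity of the group therefore matters on the 3-substituted ring, and the 3-methylphenyl compound lies furthest from the two compounds with the lowest numbers, with large steps (a 15-fold higher number from compound 2 to compound 4 (1.18 log units; beyond the scatter); a 16-fold higher number from compound 1 to compound 4 (1.20 log units; beyond the scatter)) that exceed the modest steps seen for compound 3 earlier. No measurement offered here explains why methyl and nitro differ at this place.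

The compounds shown do not tell whether the exchange of nitro for methyl would have a similar effect at the place the nitro group occupies in compound 1. For the compounds shown here, no methyl compound with that arrangement appears among them. They also leave open how an amine, a carboxylic acid or a longer chain would read in this assay at the place of the methyl group in compound 4.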